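From 4-cyanophenyl to 3-chlorophenyl: what to expect

The source may hold more compounds than are shown below. What is called first, only, known or untested is meant among the compounds shown, and "the series" means these compounds.

Measured so far in an ADME assay on GES1 cells (Homo sapiens) for cytotoxicity, read by MTT assay, with a stated time of 24 h; on this read-out higher numbers stand for lower toxicity in this test and lower numbers for higher toxicity in this test:
Compound 1 `CC1(C)[C@H]2CC[C@]1(C)N(Cc1cn(-c3ccc(C#N)cc3)nn1)C(=O)C2`: 11300 nM
Compound 2 `CC1(C)[C@H]2CC[C@]1(C)N(Cc1cn(-c3ccccc3C#N)nn1)C(=O)C2`: 9450 nM
Compound 3 `CC1(C)[C@H]2CC[C@]1(C)N(Cc1cn(-c3ccccc3F)nn1)C(=O)C2`: 5160 nM

Compound 1 stands at the high end of these three numbers, but only one of the other two compounds is clearly separated from it. Putting 2-cyanophenyl in place of 4-cyanophenyl gives a 1.2-fold lower number from compound 1 to compound 2 (0.08 log units; within the scatter), so that swap shows no real change. Putting 2-fluorophenyl there gives a 2.2-fold lower number from compound 1 to compound 3 (0.34 log units; beyond the scatter), a modest step and the only one here that clears the scatter. Fluoro in place of cyano gives a 1.8-fold lower number from compound 2 to compound 3 (0.26 log units; within the scatter).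

The unmeasured compound 4 `CC1(C)[C@H]2CC[C@]1(C)N(Cc1cn(-c3cccc(Cl)c3)nn1)C(=O)C2` changes the same spot on compound 1: 3-chlorophenyl in place of 4-cyanophenyl on an aromatic nitrogen. Compound 3, at 5160 nM, is the closest guide: it too has lost the nitrile and carries a halogen on the phenyl ring. However, no measured compound carries chlorine, so the guide is loose. A modest step down is therefore expected, and its estimated size is a 1.9-fold lower number from compound 1 to compound 4 (0.27 log units; within the scatter). For compound 4 the expected value is 6000 nM, with an estimated range of 2800 nM to 12000 nM.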

Compound 4, half-maximal cytotoxic concentration: 69800 nM
For compound 4 the middle estimate is 12-fold (1.07 log units) below the measured one; measured number outside the range, above it.
By their numbers in this assay, from the lowest: compounds 3, 2 and 1 (each within the scatter of the next, the first and the last beyond it); then compound 4.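

In this assay, going by these compounds alone, the group on the aromatic nitrogen proves able to move the number much further than the earlier compounds showed. Replacing the earlier groups with 3-chlorophenyl gives large or modest rises (a 6.2-fold higher number from compound 1 to compound 4 (0.79 log units; beyond the scatter); a 7.4-fold higher number from compound 2 to compound 4 (0.87 log units; beyond the scatter); a 14-fold higher number from compound 3 to compound 4 (1.13 log units; beyond the scatter)), and compound 4 therefore has the highest number of the four, which here means the lowest toxicity in this test. Losing the nitrile and carrying a halogen on the phenyl ring is thus no reliable sign of a lower number, as compound 3 and compound 4 share both features yet lie on opposite sides of compound 1, and nothing available here explains the difference.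

Compound 4 differs from the other compounds both in the atom on the phenyl ring and in where that atom sits, so these compounds cannot show whether the chlorine or its place matters more. Also open, on these data alone, is how a methoxy group or an amine on the same phenyl ring would read in this assay and whether it would keep the number this high.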